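This account rests on a few compounds, and the source may have more. Where it says the series, first, only, none or still open, it means among the compounds named here.

Working notes on the series. Of the compounds shown here, two have been read so far in a functional assay on A-375 cells (Homo sapiens) for inhibition, read by CCK-8 assay, with a stated time of 72 h, tested at 2 uM; on this read-out lower numbers stand for less inhibition of growth and higher numbers for more inhibition of growth at the one concentration tested. Compound 1 (`COc1ccc(SCc2ccc(C(=O)Nc3ccccc3N)cc2)cc1`) gives 10.2%, the lower of the two numbers, while compound 2 (`Nc1ccccc1NC(=O)c1ccc(CSc2nccc(C(F)(F)F)n2)cc1`) gives 54.4%, a gap beyond the usual scatter.

Compound 3 (`Nc1ccccc1NC(=O)c1ccc(CSc2ccc(Cl)cc2)cc1`) is the next to be read. It departs from compound 1 at one place, on an aromatic carbon of a six-membered aromatic ring of carbon only, para to a large group: chloro in place of methoxy, or 4-methoxyphenyl to 4-chlorophenyl (chloro in place of methoxy on an aromatic carbon).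

For the measured compounds named here, no step between measured compounds shows what this exchange does, so the expectation remains loose. Compound 1 at 10.2% leaves ample room upward, and compound 2 at 54.4% shows that the series can reach higher in this assay. A modest upward move is expected, estimated as a number 14.8 percentage points higher from compound 1 to compound 3 (beyond the scatter). For compound 3 the estimated value is 25%, with an expected range from 8% to 50%.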

Compound 3, percent growth inhibition at one concentration: 25.3%
Compound 3: the middle estimate sits 0.3 percentage points below what was measured, within the range that was stated.
By their numbers in this assay, from the lowest: compound 1; then compound 3; then compound 2.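

In this assay, for the compounds shown here, the exchange of methoxy for chloro on an aromatic carbon, para to a large group, gives the first readable step: a number 15.1 percentage points higher from compound 1 to compound 3 (beyond the scatter) with the rest of the structure unchanged. This shows that the group at this place can shift growth inhibition at the one concentration tested by more than the scatter, with chloro as the better of the two groups compared. The exchange also removes one heavy atom and one hydrogen-bond acceptor, but nothing on hand bears on which feature of the change lies behind the step.

A single step cannot show whether the gain is particular to chloro or would also appear with other groups on this same aromatic carbon, such as fluoro, methyl, trifluoromethyl or an amine. The same holds for the plain hydrogen at this place, which would show whether methoxy lowers the number, chloro raises it, or both contribute.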